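This account rests on a few compounds, and the source may have more. Where it says the series, first, only, none or still open, it means among the compounds named here.

Measured compounds:
compound 1 `C[C@@H](O)[C@H]1C(=O)N2C(C(=O)OCOC(=O)C(C)(C)C)=C(S[C@@H]3CN[C@H](C(=O)Nc4cccc(C(=O)O)c4)C3)[C@H](C)[C@H]12` — > 95%
compound 2 `CC(C)OC(=O)c1cccc(NC(=O)[C@@H]2C[C@H](SC3=C(C(=O)O)N4C(=O)[C@H]([C@@H](C)O)[C@H]4[C@H]3C)CN2)c1` — > 95%
compound 3 `CC(C)OC(=O)C1=C(S[C@@H]2CN[C@H](C(=O)Nc3cccc(C(=O)OC(C)C)c3)C2)[C@H](C)[C@@H]2[C@@H]([C@@H](C)O)C(=O)N12` — > 95%

In an ADME assay for metabolic stability, read by LC-MS, with a stated time of 3 h, at pH 6.5, tested at 50 uM (on this read-out lower numbers stand for a less stable compound and higher numbers for a more stable compound), compound 1 gives > 95%, which is a limit of the assay and not a number. In this assay compound 2 likewise gives > 95%, again a limit. Compound 3 too reaches only a limit in this assay, > 95%. Thus compound 2 stands at the same limit as the other two, and nothing separates the three on the numbers shown; all sit at the limit of > 95% in this assay, at which 3 of the 3 values shown sit.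

The step considered here goes from compound 2 to compound 4 `CC(C)C(=O)OCOC(=O)c1cccc(NC(=O)[C@@H]2C[C@H](SC3=C(C(=O)O)N4C(=O)[C@H]([C@@H](C)O)[C@H]4[C@H]3C)CN2)c1`, where (((isopropylcarbonyl)oxy)methyl in place of isopropyl on an oxygen next to a carbonyl group). For the measured compounds named here, the one measured step that bears on a change at this oxygen, a step that the two limits leave unreadable from compound 2 to compound 3, cannot be sized because both ends sit at the limit. Going by the values given here, no measured step therefore gives a readable size for this kind of change, and the expectation can rest only on the three limits.

Compound 4 is estimated at 88% in this assay, between 60% and 97%, which is expected to mean a step of a number at least 7 percentage points lower from compound 2 to compound 4 (that floor lies within the scatter) from compound 2 to compound 4 that may not exceed the usual scatter.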

Compound 4, percent of the compound remaining: > 95%
Compound 4 ended at the assay's limit (the forecaster's own chance of this, stated with the estimate: 45%); middle value at least 7 percentage points away from the limit.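

In this assay compound 4 gives > 95%, which is a limit of the assay and not a number. Compound 2 also sits at a limit, so no step from compound 2 to compound 4 can be read: the limit of > 95% in this assay, at which 4 of the 4 values shown sit.

The compounds shown leave open whether ((isopropylcarbonyl)oxy)methyl in place of isopropyl changes the result in this assay at all.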